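A Larger Group on the Oxygen of Compound 1

The compounds below may be only part of what the source reports. "The series", "measured", "known", "first", "only" and "open" are said of these compounds alone.

Compound 1 `COC/C1=C/C[C@](C)(CCC=C(C)C)/C=C/[C@@H](OC(=O)C=C(C)C)[C@](C)(O)/C=C/C1=O` gives 3950 nM in a functional assay on A549 cells (Homo sapiens) for antiproliferative activity, read by MTT assay, with a stated time of 48 h; a lower number here means a stronger inhibitor, a higher number a weaker inhibitor. Compound 2 `CC(C)=CCC[C@]1(C)/C=C/[C@@H](OC(=O)C=C(C)C)[C@](C)(O)/C=C/C(=O)/C(C(=O)O)=C\C1` reaches only the limit of > 10000 nM in this assay. Compound 3 `CC[Si](CC)(CC)C/C1=C/C[C@](C)(CCC=C(C)C)/C=C/[C@@H](OC(=O)C=C(C)C)[C@](C)(O)/C=C/C1=O` gives 3100 nM in this assay.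

Compound 1 stands at the highest of the two numbers given, with compound 3 nearest: a 1.3-fold lower number from compound 1 to compound 3 (0.11 log units; within the scatter). Compound 4 `CSC(=S)OC/C1=C/C[C@](C)(CCC=C(C)C)/C=C/[C@@H](OC(=O)C=C(C)C)[C@](C)(O)/C=C/C1=O` differs from compound 1 by a group of 4 heavy atoms (2 carbon, 2 sulfur; no ring) in place of one carbon atom, on an oxygen on a saturated carbon. Going by the values given here, two measured steps bear on it. A larger group entering on a saturated chain carbon bound to a double-bonded ring carbon gave a 1.3-fold lower number from compound 1 to compound 3 (0.11 log units; within the scatter). A carboxy in place of methoxymethyl gave an at least 2.5-fold higher number from compound 1 to compound 2 (0.40 log units; beyond the scatter), where compound 2 sits at the limit of > 10000 nM in this assay, at which 1 of the 3 values shown sits. Since the change in compound 4 keeps the oxygen and adds a group, the expectation is no step beyond the scatter: a 1.1-fold lower number from compound 1 to compound 4 (0.05 log units; within the scatter). Compound 4 is therefore estimated at 3500 nM, between 1500 nM and 8500 nM.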

Compound 4, half-maximal inhibitory concentration: 380 nM
For compound 4 the middle estimate is 9.2-fold (0.96 log units) above the measured one; measured number below the stated range.
By their numbers in this assay, from the lowest: compound 4; then compounds 3 and 1 (each within the scatter of the next). At a limit, above all of these: compound 2.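

In this assay, this oxygen on a saturated carbon proves sensitive to what it carries: the sulfur-bearing group in place of methyl gives a 10-fold lower number from compound 1 to compound 4 (1.02 log units; beyond the scatter), and the silicon-bearing group, though also larger than the methoxymethyl's methyl, does not match it, with an 8.2-fold lower number from compound 3 to compound 4 (0.91 log units; beyond the scatter). Against the carboxy group, the gap is an at least 26-fold lower number from compound 2 to compound 4 (1.42 log units; beyond the scatter). Compound 2 stands at a limit of the assay, not at a number: the limit of > 10000 nM in this assay, at which 1 of the 4 values shown sits.

On these data alone, whether the sulfur atoms matter, or only the added group on this oxygen, stays open. An acetyl ester or a longer alkyl chain on the same oxygen would separate the two.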